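Fluoro to Bromo on a Compound Without Measured Activity

The source may report more compounds than this note shows. Statements on the series, on what has been measured and on what is new or still open speak of the compounds shown alone.

Compound 1 `Fc1ccccc1NC(=S)N/N=C/c1ccc2ccccc2n1` was tested in a functional assay on HeLa cells (Homo sapiens) for antiproliferative activity, read by sulforhodamine B assay, with a stated time of 72 h; a higher number here means a weaker inhibitor, a lower number a stronger inhibitor. In this assay compound 1 gives > 100000 nM, which is a limit of the assay rather than a measured number. A second compound, compound 2 `NC(=S)N/N=C/c1ccc2cccnc2n1`, gives > 100000 nM in this assay, again a limit and not a number. Among the compounds with values here, both values therefore sit at the limit of > 100000 nM in this assay, at which 2 of the 2 values shown sit, so no measured step exists between them, and compound 1 stands at the weak end of what this assay can report. Compound 3 `S=C(N/N=C/c1ccc2ccccc2n1)Nc1ccccc1Br` has not been measured. It differs from compound 1 by bromo in place of fluoro on an aromatic carbon. Within the data shown here, with two limits and no measured step, there is no basis for expecting a change beyond the scatter in this assay. The step of a number no higher from compound 1 to compound 3 (the limit leaves the size open) is expected to be essentially none. Compound 3 is expected to give about 100000 nM, between 30000 nM and 300000 nM, most likely again reported as a limit.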

Compound 3, half-maximal inhibitory concentration: > 100000 nM
Compound 3 was reported as a limit; the forecaster's own chance of this, stated with the estimate: 80%; the middle value sits exactly at the limit.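

No new step can be read between compound 1 and compound 3, since both values are limits of the assay and not numbers: the limit of > 100000 nM in this assay, at which 3 of the 3 values shown sit.

The compounds shown leave open whether bromo in place of fluoro affects activity at all, and which change to the shared core would give a measured number in this assay.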